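Trading a Cyanophenyl Amide for a Pyridyl Amide

A few compounds are considered here, and "the series" means these few. Any claim that something is new, unique, unknown or untested is made for them only; others in the source may bear on it.

Compound 1 `Cc1cccc(C(=O)Nc2c(C(O)(C(F)(F)F)C(F)(F)F)ccc3ccccc23)c1`: 97%
Compound 2 `N#Cc1cccc(C(=O)Nc2c(C(O)(C(F)(F)F)C(F)(F)F)ccc3ccccc23)c1`: 96%

In a functional assay (Sus scrofa) with sulfonylurea receptors; K-ATP channels (Homo sapiens) as the target (on this read-out lower numbers stand for smaller maximal responses and higher numbers for larger maximal responses), compound 1 gives 97% and compound 2 gives 96%. Among the measured compounds shown here, compound 2 thus sits alongside compound 1, the only step measured being a number 1 percentage points lower from compound 1 to compound 2 (within the scatter).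

Compound 3 `O=C(Nc1c(C(O)(C(F)(F)F)C(F)(F)F)ccc2ccccc12)c1cccnc1` differs from compound 2 by pyridin-3-yl in place of 3-cyanophenyl on a carbonyl carbon. For the measured compounds named here, the single measured step bears only loosely on this change, since it swapped a group on the aromatic ring rather than the ring itself, and it stayed within the scatter. No step beyond the scatter is therefore expected in this assay. Compound 3 is estimated to give 94%, between 82% and 104%. This estimate corresponds to an expected step of a number 2 percentage points lower from compound 2 to compound 3 (within the scatter).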

Compound 3, largest response reached (reported as efficacy), in percent of the reference or control that the assay uses: 97%
For compound 3 the middle estimate is 3 percentage points below the measured one; low and high end bracket the measured number.
By their numbers in this assay, from the lowest: compounds 2, 1 and 3 (each within the scatter of the next).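

Measured in this assay, exchanging the whole ring gives small steps (a number 1 percentage points higher from compound 2 to compound 3 (within the scatter); no change at the digits printed from compound 1 to compound 3 (within the scatter)). On this carbonyl carbon, then, a six-membered aromatic ring with a hetero atom matches the carbon-only rings within the scatter, which goes further than the earlier swap of a group on the ring. No measured evidence is available to explain this result. The compounds shown leave open whether a non-aromatic group on the same carbonyl carbon, such as cyclohexyl or a short chain ending in an amine, would give a similar maximal response.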